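Methyl on the cyclobutyl carbamate of compound 2

A few compounds are considered here, and "the series" means these few. Any claim that something is new, unique, unknown or untested is made for them only; others in the source may bear on it.

Measured compounds:
compound 1 `CC1(OC(=O)N2C[C@H]3COC[C@@H](C2)[C@@H]3Oc2ncnc(Nc3ccccc3F)c2F)CC1`, 76%
compound 2 `N#Cc1ccc(Nc2ncnc(OC3C4COCC3CN(C(=O)OC3CCC3)C4)c2F)c(Cl)c1`, 60%
compound 3 `COc1c(Nc2ccc(S(C)(=O)=O)cc2F)ncnc1OC1C[C@@H]2COC[C@@H](C1)N2C(=O)OC1(C)CC1`, 79%

The series shares one core carrying a carbamate on a bridged amine and an aniline on the pyrimidine. In a functional assay for agonist activity at Glucose-dependent insulinotropic receptor (Mus musculus), read by cAMP accumulation (on this read-out lower numbers stand for smaller maximal responses and higher numbers for larger maximal responses), compound 1 gives 76%, compound 3 gives 79%, and compound 2 gives 60%. Compound 2 stands lowest of the three: its nearest neighbour is compound 1, higher by a margin beyond the scatter, and compound 3 lies further still, also beyond the scatter. Compound 1 and compound 3 sit within the scatter of each other, so no order is claimed between them.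

Compound 4 `CC1(OC(=O)N2CC3COCC(C2)C3Oc2ncnc(Nc3ccc(C#N)cc3Cl)c2F)CCC1` has not been measured. It differs from compound 2 by methyl in place of hydrogen on a saturated ring carbon. Among the measured compounds shown here, compound 1 carries the 1-methylcyclobutyl carbamate and compound 3 the 1-methylcyclopropyl carbamate, but both differ from compound 2 in the aniline as well, so no single step isolates the methyl. For the measured compounds named here, no measured pair differs in this one place alone, and a change of one carbon on a saturated ring is expected to move this assay little, if at all, beyond the scatter. The expected step of a number 6 percentage points higher from compound 2 to compound 4 (within the scatter) is therefore small and upward, with the value of compound 4 estimated at 66%, in a range from 50% to 82%.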

Compound 4, largest response reached (reported as percent of maximum), in percent of the reference or control that the assay uses: 88%
Compound 4: the middle estimate sits 22 percentage points below what was measured; the whole stated range lies below it.
By their numbers in this assay, from the lowest: compound 2; then compounds 1, 3 and 4 (each within the scatter of the next, the first and the last beyond it).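

In this assay, the change from cyclobutyl to 1-methylcyclobutyl, methyl in place of hydrogen on a saturated ring carbon of a four-membered ring, gives a number 28 percentage points higher from compound 2 to compound 4 (beyond the scatter). Among the compounds shown here, this is the first pair that differs in this one place alone, so this ring carbon of the carbamate now stands as a position where a single added methyl moves the maximal response, a reading that the earlier compounds, which also differ in the aniline, could not give. Nothing at hand bears on the reason for this step, so it stands here as an observation only.

The step rests on one pair with one aniline, and the compounds shown leave open whether the same methyl gives a similar step with a different aniline or on the cyclopropyl carbamate. Also open, from the compounds shown here alone, is whether an ethyl, a hydroxymethyl or an aminomethyl group on the same ring carbon would keep, extend or lose the step.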